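Benzyl to furylmethyl on the amine side chain

The source may report more compounds than this note shows. Statements on the series, on what has been measured and on what is new or still open speak of the compounds shown alone.

Compound 3 `COc1ccc(F)cc1CNCCCNc1ccnc2cc(-c3cccc4ccccc34)ccc12` gives 237 10^-6 cm/s in an ADME assay for permeability, using PAMPA, with a stated time of 30 min, at pH 7.4; on this read-out lower numbers stand for lower permeability and higher numbers for higher permeability. Compound 1 `FC(F)(F)c1ccc(-c2ccc3c(NCCCNCc4ccco4)ccnc3c2)cc1` gives 237 10^-6 cm/s in this assay, level with compound 3 at the digits given, and together the two stand highest of the three numbers; compound 2 `Cc1cc(C)cc(Cc2ccc3c(NCCCNCc4ccco4)ccnc3c2)c1` gives 23 10^-6 cm/s, a markedly lower number. Among the compounds with values here, the only step between measured compounds that differ in one place, a 10-fold lower number from compound 1 to compound 2 (1.01 log units; beyond the scatter), concerns the group on an aromatic carbon of the shared core. Compound 4 `c1coc(CNCCCNc2ccnc3cc(-c4cccc5ccccc45)ccc23)c1` differs from compound 3 at a different place: furan-2-yl in place of 5-fluoro-2-methoxyphenyl on a saturated chain carbon bound to an amine nitrogen. Within the data shown here, no measured step touches this position. Compound 1 carries the same (furan-2-yl)methyl group as compound 4 while compound 3 carries the 5-fluoro-2-methoxybenzyl group, and the numbers of compound 1 and compound 3 do not differ. The step from compound 3 to compound 4 is therefore expected to stay within the scatter, a 1.2-fold lower number from compound 3 to compound 4 (0.07 log units; within the scatter). For compound 4 the estimated value in this assay is 200 10^-6 cm/s, with a range from 100 10^-6 cm/s to 320 10^-6 cm/s.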

Compound 4, apparent permeability: 237 10^-6 cm/s
The estimate for compound 4 lay 1.2-fold (0.07 log units) below the measured number, within the range that was stated.
By their numbers in this assay, from the lowest: compound 2; then compounds 1, 3 and 4 (each within the scatter of the next).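

In this assay, within the data shown here, the exchange of 5-fluoro-2-methoxyphenyl for furan-2-yl on a saturated chain carbon bound to an amine nitrogen gives no change at the digits printed from compound 3 to compound 4 (within the scatter) and is the first direct reading at this place, where a smaller ring leaves the number in place. With the (furan-2-yl)methyl group held, changes of the group on an aromatic carbon give no change at the digits printed from compound 1 to compound 4 (within the scatter) and a 10-fold higher number from compound 2 to compound 4 (1.01 log units; beyond the scatter) so that, among these compounds, only steps involving 3,5-dimethylbenzyl lie beyond the scatter. Nothing measured here explains these numbers.

On these data alone, a carboxylic acid or a piperidine ring in place of furan-2-yl remains open, as does a longer chain on the amine side. Also open, as far as these compounds go, is whether 3,5-dimethylbenzyl would give a step of the same size alongside the 5-fluoro-2-methoxybenzyl group.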